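This account rests on a few compounds, and the source may have more. Where it says the series, first, only, none or still open, it means among the compounds named here.

Measured compounds and values in an assay on U-937 cells for inhibition of Fatty-acid amide hydrolase 1 (Homo sapiens), read by scintillation counting, with a stated time of 15 min; a lower number here means a stronger inhibitor, a higher number a weaker inhibitor:
compound 1, `Cc1ccc(C(=O)NC2CCCCCC2)c(=O)n1Cc1ccc(F)cc1`, > 10000 nM
compound 2, `Cc1nc(OCc2ccc(F)cc2)c(C(=O)NC2CCCCCC2)cc1-c1ccc(F)cc1`, > 10000 nM

The value of compound 1 in this assay is only a limit. The value of compound 2 in this assay is likewise only a limit. Compound 2 therefore stands at the edge of what this assay reports, and the other value shown sits there too: the limit of > 10000 nM in this assay, at which 2 of the 2 values shown sit. Compound 3, `Cc1ccc(C(=O)NC2CCCCCC2)c(OCc2ccc(F)cc2)n1`, differs from compound 2 by hydrogen in place of 4-fluorophenyl on an aromatic carbon. Among the compounds with values here, no pair of measured compounds shows what such a change does here, so nothing beyond the scatter is expected in either direction; the step from a step that the limit leaves unreadable from compound 2 to compound 3 is an estimate only. Given that compound 2 gives > 10000 nM, compound 3 is expected to give about 15000 nM in this assay, with a plausible range from 3000 nM to 60000 nM, most likely again reported only as a limit.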

Compound 3, half-maximal inhibitory concentration: > 10000 nM
Compound 3 was reported as a limit (the forecaster's own chance of this, stated with the estimate: 75%); the middle value does not contradict the limit.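

Within the data shown here, compound 2 and compound 3 are both reported only as limits in this assay, so no step between them can be read: the limit of > 10000 nM in this assay, at which 3 of the 3 values shown sit.
The compounds shown leave open what hydrogen in place of 4-fluorophenyl does to inhibition, and how strongly, if at all, any of the three compounds inhibits.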